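Swapping the side chain while cytotoxicity stays out of reach

This account rests on a few compounds, and the source may have more. Where it says the series, first, only, none or still open, it means among the compounds named here.

This study follows a small family of compounds that share one core and differ in the group carried on a saturated chain carbon bound to a sulfur. Compound 1, `Cc1c(Cc2c(F)cccc2F)nc(SCc2ccc([N+](=O)[O-])cc2)[nH]c1=O`, carries a 4-nitrophenyl group there. In an ADME assay on MT4 cells (Homo sapiens) for cytotoxicity, read by MTT assay (a lower number here means that less compound is tolerated, a higher number that more compound is tolerated), compound 1 gives > 37000 nM, which is a limit of the assay rather than a measured number. Compound 2, `CCc1c(Cc2c(Cl)cccc2Cl)nc(SCC(=O)c2ccccc2)[nH]c1=O`, carries a benzoyl group in that place and has a different core. In this assay compound 2 gives > 52000 nM, again a limit and not a number. Because both values are limits, compound 1 cannot be placed above or below compound 2: one sits at the limit of > 37000 nM in this assay, at which 1 of the 2 values shown sits, and the other at the limit of > 52000 nM in this assay, at which 1 of the 2 values shown sits.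

Compound 3, `Cc1c(Cc2c(F)cccc2F)nc(SCC(=O)c2ccccc2)[nH]c1=O`, has not yet been measured. It differs from compound 1 by benzoyl in place of 4-nitrophenyl on a saturated chain carbon bound to a sulfur. Among the measured compounds shown here, no step between measured compounds is available, so the expectation rests on the two limits alone. The step that the limit leaves unreadable from compound 1 to compound 3 is expected to stay within the scatter, with no clear direction. Compound 3 is therefore estimated at 60000 nM, within a range from 30000 nM to 150000 nM.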

Compound 3, half-maximal cytotoxic concentration: 65000 nM
Compound 3: middle estimate off by 1.1-fold (0.03 log units), on the low side; the measured number falls inside the stated range.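

Among the compounds shown here, compound 1 stands at a limit in this assay, > 37000 nM, and not at a number, so the swap of 4-nitrophenyl for benzoyl that leads to compound 3 gives no step whose size can be read. The compounds shown leave open whether this swap changes the tolerated concentration at all, and in which direction.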